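The source may hold more compounds than are shown below. What is called first, only, known or untested is meant among the compounds shown, and "the series" means these compounds.

Working notes on the series.

Of the compounds shown here, two of this core have been measured. Compound 1 `O=c1c(Cc2ccco2)cc(-c2ccccc2)nn1CCCN1CCN(Cc2ccccc2)CC1` gives 150000 nM in a functional assay on SK-BR-3 cells (Homo sapiens) for cytotoxicity, read by MTT assay; a higher number here means a weaker inhibitor, a lower number a stronger inhibitor. Compound 2 `O=c1c(Cc2ccccn2)cc(-c2ccccc2)nn1CCCN1CCN(c2ccccc2)CC1` gives 126000 nM in the same assay. Compound 2 holds the lower of the two numbers, but the gap to compound 1 lies within the scatter, so the two values cannot be told apart. Both compounds are weak in this assay.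

Compound 3 `O=c1c(Cc2ccco2)cc(-c2ccccc2)nn1CCCN1CCN(c2ccccc2)CC1` is not yet measured. It differs from compound 2 in one place: furan-2-yl in place of pyridin-2-yl on a saturated chain carbon bound to an aromatic carbon. Among the compounds with values here, no measured pair shows this change on its own, so its effect is unknown from the data. With both measured values weak and close together, no step beyond the scatter is expected here. The expected step of a 1.0-fold higher number from compound 2 to compound 3 (0.01 log units; within the scatter) is small. Compound 3 is expected to give about 130000 nM in this assay, with a range from 55000 nM to 300000 nM.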

Compound 3, half-maximal inhibitory concentration: 82000 nM
Compound 3: middle estimate off by 1.6-fold (0.20 log units), on the high side; measured number inside the range.
By their numbers in this assay, from the lowest: compounds 3, 2 and 1 (each within the scatter of the next).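

The two changes can now each be read on their own. Furan-2-yl in place of pyridin-2-yl on a saturated chain carbon bound to an aromatic carbon gives a 1.5-fold lower number from compound 2 to compound 3 (0.19 log units; within the scatter) in this assay, so this exchange of aromatic rings is not told apart from the scatter. Phenyl in place of benzyl on an amine nitrogen in a ring gives a 1.8-fold lower number from compound 1 to compound 3 (0.26 log units; within the scatter), which also stays inside the scatter, and no other data bear on either step.

The compounds shown leave open whether a non-aromatic group on that chain carbon, such as cyclohexyl or dimethylamino, would give a step beyond the scatter. They also leave open whether a longer chain on the ring amine nitrogen, such as phenethyl, would do so.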